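Chain shortening in vanillyl amides at the TRPV1 channel

This account rests on a few compounds, and the source may have more. Where it says the series, first, only, none or still open, it means among the compounds named here.

Measured so far:
compound 1, `COc1cc(CNC(=O)[C@H]2[C@@H](C=C(C)C)C2(C)C)ccc1O`: 200 nM
compound 2, `CCCCCCCCC#CCCCCCCCC(=O)NCc1ccc(O)c(OC)c1`: 12.6 nM

Both compounds share the vanillyl amide portion and differ in the acyl part. In a functional assay on HEK293 cells with transient receptor potential cation channel subfamily V member 1 (Homo sapiens) as the target (on this read-out higher numbers stand for an effect only at larger amounts of compound and lower numbers for an effect already at smaller amounts), compound 2 gives 12.6 nM and holds the lowest number of the pair; compound 1 gives 200 nM, a gap beyond the scatter.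

Compound 3, `C=CCCCCCCCCC(=O)NCc1ccc(O)c(OC)c1`, keeps the same amide and shortens the acyl chain: allyl in place of dec-1-yn-1-yl on a saturated chain carbon, seven bonds along the chain from a carbonyl carbon. The chain loses its triple bond and most of its length, and the terminus becomes a double bond. Among the measured compounds shown here, no measured pair isolates this change, so the step is expected from the two values alone. A weakening beyond the scatter is expected for compound 3, since the long-chain compound 2 sits at 12.6 nM while the short, branched compound 1 sits at 200 nM. The step from compound 2 to compound 3 is estimated at a 7.9-fold higher number from compound 2 to compound 3 (0.90 log units; beyond the scatter). For compound 3 the expected value is 100 nM, within 30 nM to 400 nM.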

Compound 3, half-maximal effective concentration: 2 nM
Estimate against measurement, compound 3: 50-fold (1.70 log units) above; the whole stated range lies above it.
By their numbers in this assay, from the lowest: compound 3; then compound 2; then compound 1.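

In this assay, allyl in place of dec-1-yn-1-yl on a saturated chain carbon, seven bonds along the chain from a carbonyl carbon, gives a 6.3-fold lower number from compound 2 to compound 3 (0.80 log units; beyond the scatter). This position therefore does not need the long dec-1-yn-1-yl group for a low number: in this pair, the allyl group, with fewer heavy atoms, gives a lower number than the dec-1-yn-1-yl group. The replacement also exchanges a triple bond for a double bond, so length and bond type change together and the step belongs to the whole replacement.

Nothing measured here accounts for the step. Still open, from the compounds shown here alone, is whether a propyl group, or a longer chain ending in a double bond, would keep the number of compound 3, which would separate the two changes.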